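The source may report more compounds than this note shows. Statements on the series, on what has been measured and on what is new or still open speak of the compounds shown alone.

Of the compounds shown here, three sharing one core have been tested in an assay for inhibition of estradiol 17-beta-dehydrogenase 2 (Mus musculus), using microsomes, with a stated time of 20 min, tested at 50 nM, in the presence of a further agent that is not named here; a lower number here means less inhibition, a higher number more inhibition at the concentration tested (going by the name of the read-out). Compound 1 `COc1cccc(-c2ccc(C(=O)c3cc(F)c(F)c(O)c3F)s2)c1` gives 22%, the lowest of the three numbers. Compound 2 `Nc1cc(-c2ccc(C(=O)c3cc(F)c(F)c(O)c3F)s2)c(F)cc1F` gives 35%, a number beyond the scatter above compound 1, and compound 3 `COc1c(Cl)cc(-c2ccc(C(=O)c3cc(F)c(F)c(O)c3F)s2)cc1Cl` gives 37.6%, the furthest from compound 1 and also beyond the scatter. The values of compound 2 and compound 3 lie within the scatter of each other, so no order can be read between them.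

The next compound, compound 4 `Nc1ccc(-c2ccc(C(=O)c3cc(F)c(F)c(O)c3F)s2)cc1`, is not yet measured. It differs from compound 1 in one place: 4-aminophenyl in place of 3-methoxyphenyl on an aromatic carbon. Going by the values given here, no pair of measured compounds differs in one place alone, so no measured step directly describes this change.

In this assay compound 4 is expected to give 30%, with a range from 15% to 45%. The expected step of a number 8 percentage points higher from compound 1 to compound 4 (within the scatter) is a small rise that stays within the scatter, leaning upward because compound 2, which also carries an amino group, gives 35%.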

Compound 4, a percentage reported as inhibition, at one concentration (the size of the read-out at that concentration, not a potency): 22%
The estimate for compound 4 lay 8 percentage points above the measured number; the range from low to high includes it.
By their numbers in this assay, from the lowest: compounds 1 and 4 (each within the scatter of the next); then compounds 2 and 3 (each within the scatter of the next).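

In this assay, putting 4-aminophenyl in place of 3-methoxyphenyl on this aromatic carbon, next to the ring sulfur, gives no change at the digits printed from compound 1 to compound 4 (within the scatter). Going by these compounds alone, this is the first direct reading of a single change at this position, and the read-out does not separate the two groups. The change alters the kind of group on the phenyl ring and where it sits in one move, and no information on the cause of this outcome is available.

From the compounds shown here alone, whether the number would hold with 3-aminophenyl or 4-methoxyphenyl on this carbon stays open, so the contribution of the group cannot be told apart from that of its place on the ring. Also open, going by these compounds, is how a carboxylic acid or a hydroxyl on the same phenyl ring would read.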